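Aryl replacement on the shared core: compound 3 outlook

This account rests on a few compounds, and the source may have more. Where it says the series, first, only, none or still open, it means among the compounds named here.

Compound 1 `COc1ccc(-c2ccc3ncn(-c4cc(OC)c(OC)c(OC)c4)c3c2)cc1O` is the reference in this set. In a functional assay on SGC-7901 cells (Homo sapiens) for antiproliferative activity, read by MTT assay, with a stated time of 72 h (on this read-out higher numbers stand for weaker inhibition and lower numbers for stronger inhibition), compound 1 gives 44 nM, the lowest of the two numbers recorded so far. Compound 2 `COc1cc(-n2cnc3ccc(-c4cccc(C)c4C)cc32)cc(OC)c1OC` gives 3040 nM in the same assay, and the step of a 69-fold higher number from compound 1 to compound 2 (1.84 log units; beyond the scatter) shows how strongly that position responds to exchange of the aryl group. Compound 3 `COc1cc(-n2cnc3ccc(-c4ccc(Cl)cc4)cc32)cc(OC)c1OC` differs from compound 1 in the same place: 4-chlorophenyl in place of 3-hydroxy-4-methoxyphenyl on an aromatic carbon. For the measured compounds named here, only the step from compound 1 to compound 2 bears on this change, and it was large in the direction of a higher number. The incoming 4-chlorophenyl, like the 2,3-dimethylphenyl of compound 2, carries neither hydrogen-bond donor nor acceptor, so a higher number for compound 3 is expected, though the size is uncertain with a single comparison. The step of a 34-fold higher number from compound 1 to compound 3 (1.53 log units; beyond the scatter) is the estimated shift, with compound 3 expected at about 1500 nM, within 300 nM to 7000 nM.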

Compound 3, half-maximal inhibitory concentration: 1270 nM
Compound 3: the middle estimate sits 1.2-fold (0.07 log units) above what was measured; low and high end bracket the measured number.
By their numbers in this assay, from the lowest: compound 1; then compound 3; then compound 2.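

In this assay, a second aryl group with no hydrogen-bond donor or acceptor, 4-chlorophenyl, also gives a large step away from 3-hydroxy-4-methoxyphenyl, with a 29-fold higher number from compound 1 to compound 3 (1.46 log units; beyond the scatter), so the large change at this aromatic carbon is no longer tied to 2,3-dimethylphenyl alone. The two replacements are not equivalent, with a 2.4-fold lower number from compound 2 to compound 3 (0.38 log units; beyond the scatter), a modest step beyond the scatter. No measurement at hand accounts for either step.

The compounds shown leave open whether the hydroxy group or the methoxy group of compound 1 carries the difference; a phenyl group bearing only one of the two would separate them. Also open, going by these compounds, is where an aryl group bearing an amine or a carboxylic acid would fall at this carbon.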